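This account rests on a few compounds, and the source may have more. Where it says the series, first, only, none or still open, it means among the compounds named here.

Compound 1 `CCOC1=C(/C(C)=N/OCC(=O)Nc2ccccc2)N(C)S(=O)(=O)c2ccccc21` carries a plain phenyl on an amide-type nitrogen. In a functional assay on THP-1 cells (Homo sapiens) for inhibition, read by ELISA, with stated times of 2 h and 48 h (on this read-out lower numbers stand for stronger inhibition and higher numbers for weaker inhibition), compound 1 gives a value that is a limit of the assay, > 20000 nM. Compound 2 `CCOC1=C(/C(C)=N/OCC(=O)Nc2ccc(F)c(Cl)c2)N(C)S(=O)(=O)c2ccccc21` bears 3-chloro-4-fluorophenyl in place of phenyl on that nitrogen. In this assay compound 2 likewise stands at a limit, > 20000 nM. Compound 3 `C/C(=N\OCC(=O)Nc1ccccc1)C1=C(O)c2ccccc2S(=O)(=O)N1C` has hydrogen in place of ethyl on an oxygen on an unsaturated carbon. In this assay compound 3 again sits at a limit, > 20000 nM. Compound 3 therefore stands nowhere readable among the numbers shown: the step that the two limits leave unreadable from compound 1 to compound 3 and the step that the two limits leave unreadable from compound 1 to compound 2 are both unreadable, since all of the values sit at the same limit (the limit of > 20000 nM in this assay, at which 3 of the 3 values shown sit).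

Compound 4 `C/C(=N\OCC(=O)Nc1ccc(Cl)c(C(F)(F)F)c1)C1=C(O)c2ccccc2S(=O)(=O)N1C` differs from compound 3 by 4-chloro-3-(trifluoromethyl)phenyl in place of phenyl on an amide-type nitrogen. Going by the values given here, the one measured step that touches the amide-type nitrogen, a step that the two limits leave unreadable from compound 1 to compound 2, has no readable size, so it offers no direction for the change to compound 4. Compound 4 is therefore expected to stay at or near the limit, with an estimated step that the limit leaves unreadable from compound 3 to compound 4 that cannot be taken as beyond the scatter. Compound 4 is estimated at 30000 nM, with a range from 5000 nM to 200000 nM.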

Compound 4, half-maximal inhibitory concentration: > 20000 nM
Compound 4: a limit, no number; the forecaster's own chance of this, stated with the estimate: 80%; the middle value does not contradict the limit.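

In this assay compound 4 gives > 20000 nM, a limit of the assay and not a number. The step from compound 3 to compound 4 therefore cannot be read, and every value shown stands at the same limit: the limit of > 20000 nM in this assay, at which 4 of the 4 values shown sit. The compounds shown leave open whether any of these changes alters inhibition in this assay.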